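Cinnamamide Aryl Swap: Trifluoromethyl to Difluoro

This account rests on a few compounds, and the source may have more. Where it says the series, first, only, none or still open, it means among the compounds named here.

Measured compounds:
compound 1 `COc1ccc(C(=O)c2cc(OC)c(OC)c(OC)c2)cc1NC(=O)/C=C/c1ccc(OC)c(OC)c1` — 2500 nM
compound 2 `COc1ccc(C(=O)c2cc(OC)c(OC)c(OC)c2)cc1NC(=O)/C=C/c1ccc(C(F)(F)F)cc1` — 1600 nM

In a functional assay on HT-29 cells (Homo sapiens) for cytotoxicity, read by MTT assay, with a stated time of 72 h (a higher number here means a weaker inhibitor, a lower number a stronger inhibitor), compound 1 gives 2500 nM and compound 2 gives 1600 nM. Among the compounds with values here, the one step between them, a 1.6-fold lower number from compound 1 to compound 2 (0.19 log units; within the scatter), is within the scatter, so compound 2 stands alongside compound 1 rather than apart from it, and the two numbers cannot be ordered.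

Compound 3 `COc1ccc(C(=O)c2cc(OC)c(OC)c(OC)c2)cc1NC(=O)/C=C/c1ccc(F)c(F)c1` differs from compound 2 by 3,4-difluorophenyl in place of 4-(trifluoromethyl)phenyl on a double-bonded chain carbon bound to a double-bonded chain carbon. Within the data shown here, the only measured step that bears on an exchange of the aryl group on the double-bonded chain carbon is a 1.6-fold lower number from compound 1 to compound 2 (0.19 log units; within the scatter), and it did not leave the scatter. On that basis no step beyond the scatter is expected in this assay, in either direction, so the estimated step of a 1.1-fold higher number from compound 2 to compound 3 (0.05 log units; within the scatter) is small. Compound 3 is therefore expected to give about 1800 nM, with a range from 700 nM to 4500 nM.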

Compound 3, half-maximal inhibitory concentration: 4200 nM
The estimate for compound 3 lay 2.3-fold (0.37 log units) below the measured number, and the stated range covers the measured number.
By their numbers in this assay, from the lowest: compounds 2, 1 and 3 (each within the scatter of the next, the first and the last beyond it).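

In this assay the exchange of the aryl group on the double-bonded chain carbon now gives a step beyond the scatter, a 2.6-fold higher number from compound 2 to compound 3 (0.42 log units; beyond the scatter), so this position does distinguish between aryl groups, which the earlier pair could not show. The separation is modest and holds only for this pair: a 1.7-fold higher number from compound 1 to compound 3 (0.23 log units; within the scatter) stays within the scatter, so compound 1 cannot be ordered against compound 3 any more than against compound 2. Nothing available explains why 4-(trifluoromethyl)phenyl and 3,4-difluorophenyl part in this way.

The compounds shown leave open how an aryl group carrying a nitrile, an amine or a carboxylic acid would read at this position. They also leave open whether the same separation between compound 2 and compound 3 would appear in other cells.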